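This account rests on a few compounds, and the source may have more. Where it says the series, first, only, none or still open, it means among the compounds named here.

Measured compounds in the series:

- compound 1, `Cc1c(CC(C)C)c(=O)on1C(=O)N1CCCCC1`: 5 nM
- compound 2, `Cc1c(C2CCOCC2)c(=O)on1C(=O)N1CCCCC1`: 71 nM
- compound 3, `CSc1nc(-c2ccc(Cl)cc2)nn1C(=O)N1CCCCC1`: 1.76 nM

All three were read in an assay (strain Wistar) for inhibition of Hormone-sensitive lipase (Rattus norvegicus), read by spectrophotometry; a lower number here means a stronger inhibitor, a higher number a weaker inhibitor. Compound 3 gives the lowest number of the three; compound 1 stands nearest to it, and compound 2 stands furthest away. Compound 1 and compound 2 share one core and differ only at one aromatic carbon, where the change a 14-fold higher number from compound 1 to compound 2 (1.15 log units; beyond the scatter) raised the number well beyond the scatter. Compound 3 sits on a different core and is not linked to either of them by a single-point step.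

The unmeasured compound 4, `O=C(N1CCCCC1)n1nc(-c2ccc(Cl)cc2)nc1SC1CCCCC1`, is derived from compound 3 by the change (cyclohexyl in place of methyl on a sulfur). Going by the values given here, no measured step on this core, at this sulfur, or with this pair of groups is available. Among the compounds with values here, the only measured step, from compound 1 to compound 2, swaps a chain for a six-membered ring at a different place on a different core and gave a large rise in the number; it bears on the present step only loosely. The step is therefore treated as open, with a wide range, and a modest rise is taken as the expected direction, giving a 2.8-fold higher number from compound 3 to compound 4 (0.45 log units; beyond the scatter) as the expected step. For compound 4 the estimated value in this assay is 5 nM, within 1 nM to 30 nM.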

Compound 4, half-maximal inhibitory concentration: 882 nM
Beside the measured number, compound 4's estimate is 180-fold (2.25 log units) below it, outside the stated range (above it).
By their numbers in this assay, from the lowest: compound 3; then compound 1; then compound 2; then compound 4.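

On the core of compound 3, the group on the sulfur is the first position in the series shown to control the reading in this assay this strongly: methylsulfanyl to cyclohexylsulfanyl gives a 500-fold higher number from compound 3 to compound 4 (2.70 log units; beyond the scatter), turning the lowest number of the four into the highest. The earlier step, a 14-fold higher number from compound 1 to compound 2 (1.15 log units; beyond the scatter), also brought in a six-membered ring, there on an aromatic carbon of a different core, so in both single-point steps shown the entry of such a ring goes with a higher number, and neither step goes against this; two steps at two unrelated places do not make a rule. No measurement at hand accounts for the size of the step at the sulfur.

Still open, on these data alone, is how the number moves between methyl and cyclohexyl, which an ethyl group or a longer open chain on the sulfur would help to place, and whether it is the ring or the count of carbons that tracks the rise. Also open, as far as these compounds go, is whether a cyclohexyl ring carrying an amine or a carboxylic acid would read like the bare ring at this sulfur.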